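Ester placement on the distal phenyl ring

The compounds below may be only part of what the source reports. "The series", "measured", "known", "first", "only" and "open" are said of these compounds alone.

Measured so far:
compound 1 `CCCc1ccc(-c2ccc(N(C[C@@H](N)[C@@H](C)CC)C(=O)[C@@H]3C[C@H]3c3ccccc3)cc2)cc1`, a functional assay for agonist activity at G protein-coupled receptor 88 (Homo sapiens), read by HTRF and cAMP accumulation; a lower number here means that less compound is needed, a higher number that more compound is needed for the effect: 61 nM
compound 2 `CC[C@H](C)[C@H](N)CN(C(=O)[C@@H]1C[C@H]1c1ccccc1)c1ccc(-c2ccc(CCC(=O)OC)cc2)cc1`, this assay: 110 nM

Compound 2 carries the higher of the two numbers, but the step of a 1.8-fold higher number from compound 1 to compound 2 (0.26 log units; within the scatter) is within the scatter, so the two compounds are not distinguished. Compound 3 `CCOC(=O)c1ccc(-c2ccc(N(C[C@@H](N)[C@@H](C)CC)C(=O)[C@@H]3C[C@H]3c3ccccc3)cc2)cc1` differs from compound 2 by ethoxycarbonyl in place of 2-(methoxycarbonyl)ethyl on an aromatic carbon. Going by the values given here, no measured step touches an aromatic carbon; the only step available, a 1.8-fold higher number from compound 1 to compound 2 (0.26 log units; within the scatter), altered a saturated chain and stayed within the scatter. Hence no step beyond the scatter is expected for the move to compound 3, a 1.1-fold lower number from compound 2 to compound 3 (0.04 log units; within the scatter). For compound 3 the estimate is 100 nM, with a range from 40 nM to 300 nM.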

Compound 3, half-maximal effective concentration: 260 nM
Beside the measured number, compound 3's estimate is 2.6-fold (0.41 log units) below it, within the range that was stated.
By their numbers in this assay, from the lowest: compounds 1 and 2 (each within the scatter of the next); then compound 3.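

With ethoxycarbonyl on the aromatic carbon, this assay shows a 2.4-fold higher number from compound 2 to compound 3 (0.37 log units; beyond the scatter) and a 4.3-fold higher number from compound 1 to compound 3 (0.63 log units; beyond the scatter) against the two earlier groups. This position therefore responds to the group it carries, which the change from propyl to 2-(methoxycarbonyl)ethyl alone did not show. Nothing at hand accounts for the shift.

Compound 2 and compound 3 differ in both the ester's alkyl part and its chain link to the ring, so neither can be singled out as what matters. On these data alone, how a carboxylic acid or an amine on this aromatic carbon would read remains open.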